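The source may hold more compounds than are shown below. What is called first, only, known or untested is meant among the compounds shown, and "the series" means these compounds.

Values so far in a functional assay on HL-60 cells (Homo sapiens) for inhibition, read by MTT assay, with a stated time of 72 h (a higher number here means a weaker inhibitor, a lower number a stronger inhibitor), are:
- compound 1 (`Cc1nc(-c2ccccc2)c(C(=O)N2CCN(c3cccc(Cl)c3)CC2)o1`) gives 39.2 nM as its reading
- compound 2 (`C=C(C)c1ccc(N2CCN(C(=O)c3oc(C)nc3-c3ccccc3)CC2)cc1`) gives "not active" (no number reported) as its reading

Compound 2 has no single number in this assay and so cannot be placed on the scale. Compound 3 (`Cc1ccc(N2CCN(C(=O)c3oc(C)nc3-c3ccccc3)CC2)cc1`) differs from compound 2 in one place, with methyl in place of 1-methylethenyl on an aromatic carbon, para to a large group (methyl in place of 1-methylethenyl on an aromatic carbon).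

Going by the values given here, no measured step links any two compounds here, so the size of this change cannot be read from the data. A move towards stronger inhibition than compound 2 is expected in this assay, although a second reading without a number remains possible. Among the compounds with values here, the only numeric anchor is compound 1 at 39.2 nM on the shared core. For compound 3 the estimated value is 200 nM (expected range 20 nM to 3000 nM).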

Compound 3, half-maximal inhibitory concentration: > 1000 nM
Compound 3: only a limit was reported; the forecaster's own chance of this, stated with the estimate: 30%; middle value at least 5.0-fold (0.69 log units) away from the limit.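

In this assay compound 3 gives > 1000 nM, which is a limit and not a number: the limit of > 1000 nM in this assay, at which 1 of the 3 values shown sits. Swapping 3-chlorophenyl on the ring amine nitrogen for 4-methylphenyl gives an at least 25-fold higher number from compound 1 to compound 3 (1.40 log units; beyond the scatter), so this position on the shared core does not tolerate every aryl group, and the size of the step is known only as a minimum. With compound 2 reading "not active" (no number reported), neither of the two compounds carrying a group para to the large group has a numeric value, and the step from 1-methylethenyl to methyl cannot be read.

The step from compound 1 changes both the substituent and its place on the ring, so the compounds shown do not separate these two effects. A 3-methylphenyl or 4-chlorophenyl on the same nitrogen would bear on that question.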